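The source may report more compounds than this note shows. Statements on the series, on what has been measured and on what is new or still open speak of the compounds shown alone.

Measured compounds:
Compound 1 `Cc1nnc(NC(N)=O)cc1Cc1ccccc1` with 20 mg/kg
Compound 2 `Cc1nn2cnnc2cc1Cc1ccccc1` with 20 mg/kg

In a functional assay on the whole organism with Mus musculus as the target (a higher number here means that more compound is needed for the effect, a lower number that less compound is needed), compound 1 gives 20 mg/kg. Compound 2 is a close relative in which the side chain attached to the shared core of compound 1 has been folded into a second ring fused onto it. In this assay compound 2 gives 20 mg/kg, which is level with compound 1 at the digits shown; the two values sit within the usual scatter of this kind of measurement, so no difference between them can be read from these numbers. One further compound, compound 3 `Cc1nn2c(N)nnc2cc1Cc1ccccc1`, has not yet been measured in this assay. It differs from compound 2 in one place: amino in place of hydrogen on an aromatic carbon. Among the measured compounds shown here, no measured pair shows what this kind of change does here, so there is no basis for expecting a step in either direction, and the safest expectation is a step that stays within the scatter. The expected step is no change at the digits printed from compound 2 to compound 3 (within the scatter), none beyond the scatter. Compound 3 is therefore estimated at 20 mg/kg, with a range from 8 mg/kg to 50 mg/kg.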

Compound 3, dose for half-maximal effect: 20 mg/kg
Estimate against measurement, compound 3: no gap at the digits printed; the measured number falls inside the stated range.
By their numbers in this assay, from the lowest: compounds 1, 2 and 3 (each within the scatter of the next).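

Among the compounds shown here, replacing hydrogen with amino on the aromatic carbon between two ring nitrogen atoms gives, in this assay, no change at the digits printed from compound 2 to compound 3 (within the scatter) and this is the first measured pair to show what this change does here. The earlier compounds shown here said nothing about this carbon, whereas this pair shows that it can carry an amino group with no difference that can be read from this measurement. Nothing measured alongside these compounds explains this result, so the pair records only the outcome and not what lies behind it.

This is a single change at a single place, so it cannot show whether the carbon would accept other groups in the same way, and it sets no rule for the series. A methyl group, a dimethylamino group, a longer chain such as butylamino or a carboxylic acid at this carbon could each give a similar value or a clearly different one, and only measured compounds carrying such groups could tell how much room for change this position really has.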